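A Thiophene Ring Replaces a Hydroxyphenyl Group

This account rests on a few compounds, and the source may have more. Where it says the series, first, only, none or still open, it means among the compounds named here.

Of the compounds shown here, three have so far been measured in a functional assay on HCT-116 cells (Homo sapiens) for antiproliferative activity, read by CellTiter-Glo, with a stated time of 72 h; a lower number here means a stronger inhibitor, a higher number a weaker inhibitor. Compound 1 `O=C(NO)c1cccc(/C=C/c2ccnc(-c3cc(F)ccc3O)c2)c1` gives 3890 nM, compound 2 `O=C(NO)c1ccc(/C=C/c2ccnc(-c3cccc(O)c3)c2)cc1` gives 1610 nM, and compound 3 `Cc1ccc(-c2cc(/C=C/c3ccc(C(=O)NO)cc3)c(F)cn2)c(F)c1` gives 1670 nM. Compound 2 has the lowest number of the three, but its gap to compound 3 lies within the scatter, so these two cannot be told apart; only compound 1 stands clearly higher, beyond the scatter.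

Compound 4 `O=C(NO)c1ccc(/C=C/c2ccnc(-c3ccsc3)c2)cc1` awaits measurement. It differs from compound 2 in one place: thiophen-3-yl in place of 3-hydroxyphenyl on an aromatic carbon. The group that leaves carries a hydrogen-bond donor and a six-membered ring of carbon only; the group that enters carries no donor and a five-membered ring with one hetero atom.

Within the data shown here, no measured pair shows what such an exchange does, so the expectation rests on compound 2 alone. Compound 4 is expected to land near 2500 nM, within a range from 800 nM to 8000 nM. The expected step is a 1.6-fold higher number from compound 2 to compound 4 (0.19 log units; within the scatter), a modest move toward a higher number that may still fall within the scatter.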

Compound 4, half-maximal inhibitory concentration: 1910 nM
Compound 4: the middle estimate sits 1.3-fold (0.12 log units) above what was measured; the measured number falls inside the stated range.
By their numbers in this assay, from the lowest: compounds 2, 3 and 4 (each within the scatter of the next); then compound 1.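

Among these compounds, this pair is the first to differ in one place, and it gives a direct reading of a change on the aromatic carbon next to the ring nitrogen: in this assay the exchange gives a 1.2-fold higher number from compound 2 to compound 4 (0.07 log units; within the scatter). At this position, therefore, thiophen-3-yl, with no hydrogen-bond donor and a five-membered ring, cannot be told apart from 3-hydroxyphenyl, with its donor and six-membered ring. Nothing measured here gives a reason for this match.

On these data alone, whether this place needs an aromatic ring at all remains open, and a group such as a carboxylic acid or a piperidine ring could test that. As far as these compounds go, it is also open whether the same exchange would give a similar result on the core of compound 1 or compound 3.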